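The compounds below may be only part of what the source reports. "The series", "measured", "known", "first", "only" and "open" are said of these compounds alone.

Measured so far in a functional assay on 1321-N1 cells for agonist activity at P2Y purinoceptor 6 (Homo sapiens), read by scintillation counting and inositol phosphate accumulation; on this read-out lower numbers stand for an effect already at smaller amounts and higher numbers for an effect only at larger amounts of compound:
compound 1 `O=C(O)CCCO/N=c1/ccn([C@@H]2O[C@H](COP(=O)(O)OP(=O)(O)OP(=O)(O)O)[C@@H](O)[C@H]2O)c(=O)[nH]1` — compound 1 gives 697 nM
compound 2 `O=c1[nH]/c(=N\OCCCc2cccc(F)c2)ccn1[C@@H]1O[C@H](COP(=O)(O)OP(=O)(O)OP(=O)(O)O)[C@@H](O)[C@H]1O` — compound 2 gives 539 nM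
compound 3 `O=c1[nH]/c(=N\OCCCc2ccc([N+](=O)[O-])cc2)ccn1[C@@H]1O[C@H](COP(=O)(O)OP(=O)(O)OP(=O)(O)O)[C@@H](O)[C@H]1O` — compound 3 gives 1330 nM

Compound 3 stands at the highest of the three numbers: against compound 1 it sits within the scatter, a 1.9-fold higher number from compound 1 to compound 3 (0.28 log units; within the scatter); against compound 2 it sits beyond it, a 2.5-fold higher number from compound 2 to compound 3 (0.39 log units; beyond the scatter).

Compound 4 `O=c1[nH]/c(=N\OCCCc2cccnc2)ccn1[C@@H]1O[C@H](COP(=O)(O)OP(=O)(O)OP(=O)(O)O)[C@@H](O)[C@H]1O` differs from compound 3 by pyridin-3-yl in place of 4-nitrophenyl on a saturated chain carbon, three bonds along the chain from an oxygen. Among the compounds with values here, no measured step carries a pyridin-3-yl. Within the data shown here, the one aryl-for-aryl step at this place, a 2.5-fold higher number from compound 2 to compound 3 (0.39 log units; beyond the scatter), was modest, and the carboxy-to-aryl steps, a 1.3-fold lower number from compound 1 to compound 2 (0.11 log units; within the scatter) and a 1.9-fold higher number from compound 1 to compound 3 (0.28 log units; within the scatter), stayed within the scatter. Compound 4 is therefore expected to return toward the other two numbers, an expected step of a 1.8-fold lower number from compound 3 to compound 4 (0.25 log units; within the scatter) in this assay. The estimate for compound 4 is 750 nM, with a range of 300 nM to 1900 nM.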

Compound 4, half-maximal effective concentration: 2950 nM
Compound 4: the middle estimate sits 3.9-fold (0.59 log units) below what was measured; measured number outside the range, above it.
By their numbers in this assay, from the lowest: compounds 2, 1 and 3 (each within the scatter of the next, the first and the last beyond it); then compound 4.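

In this assay, within the data shown here, this place on the chain tolerates less than the earlier compounds suggested: pyridin-3-yl gives the highest number of the series (a 2.2-fold higher number from compound 3 to compound 4 (0.35 log units; beyond the scatter)), and the step also stands beyond the scatter against the other two compounds (a 5.5-fold higher number from compound 2 to compound 4 (0.74 log units; beyond the scatter); a 4.2-fold higher number from compound 1 to compound 4 (0.63 log units; beyond the scatter)). Compound 4 is the only one of the four with a hetero atom in its six-membered aromatic ring, while the two carbon-only rings of compound 2 and compound 3 give lower numbers.

No measurement shown accounts for this rise. A plain phenyl or a pyridin-4-yl on the same chain would show whether the ring nitrogen or its location drives the step.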